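The source may hold more compounds than are shown below. What is called first, only, known or untested is meant among the compounds shown, and "the series" means these compounds.

Three compounds share one core and were tested in an assay on membranes from CHO cells for displacement of a labelled ligand from adenosine receptor A1 (Homo sapiens), read by scintillation counting, with a stated time of 60 min, tested at 1 uM; a lower number here means less inhibition, a higher number more inhibition at the concentration tested (going by the name of the read-out). Compound 1, `CC1=C(C(=O)C2CC2)C(c2ccsc2)NC(=O)N1`, gives 2%. Compound 2, `CCN(CC)C(=O)C1=C(C)NC(=O)NC1c1cccs1`, gives 13%. Compound 3, `CCNC(=O)C1=C(C)NC(=O)NC1c1ccsc1`, gives 3%. On these numbers compound 3 stands second highest of the three: its nearest neighbour is compound 1, whose number lies a little lower, and its furthest is compound 2, whose number lies higher, yet both gaps fall within the scatter of this kind of measurement, so none of the three can be told apart with confidence.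

Among the measured compounds shown here, the one measured step that changes a single place, a number 1 percentage points higher from compound 1 to compound 3 (within the scatter), also stayed within the scatter.

Compound 4, `CCN(CC)C(=O)C1=C(C)NC(=O)NC1c1ccsc1`, has not yet been measured. It differs from compound 3 by ethyl in place of hydrogen on an amide-type nitrogen. For the measured compounds named here, no measured pair shows exactly this change on this core, so the step from compound 1 to compound 3 is the only guide, and it was small. Compound 2 carries the same diethylamino group on an otherwise slightly different core and gives a number within the scatter of compound 3.

The expected step is therefore small, a number 5 percentage points higher from compound 3 to compound 4 (within the scatter), with no direction beyond the scatter. Compound 4 is estimated to give 8%, expected to lie between 0% and 20%.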

Compound 4, a percentage reported as inhibition, at one concentration (the size of the read-out at that concentration, not a potency): 11%
For compound 4 the middle estimate is 3 percentage points below the measured one, and the stated range covers the measured number.
By their numbers in this assay, from the lowest: compounds 1, 3, 4 and 2 (each within the scatter of the next, the first and the last beyond it).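

In this assay, ethyl in place of hydrogen on an amide-type nitrogen, which turns ethylamino into diethylamino, can now be read on a single core, and it gives a number 8 percentage points higher from compound 3 to compound 4 (within the scatter); this change at this position therefore leaves the read-out inside the usual spread of repeat measurements. With the diethylamino group held the same, thiophen-3-yl in place of thiophen-2-yl on a saturated ring carbon gives a number 2 percentage points lower from compound 2 to compound 4 (within the scatter), so the two thiophene groups cannot be told apart in this assay. Diethylamino in place of cyclopropyl on a carbonyl carbon gives a number 9 percentage points higher from compound 1 to compound 4 (within the scatter), so this swap, like the ethylamino swap at the same carbon, cannot be told apart from no change.

No measurement is available to explain these small numbers. The compounds shown leave open whether a butyl chain or a benzyl group on the amide-type nitrogen would give a number that stands clear of the scatter, and whether any such compound would differ from compound 3 by a step large enough to read.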